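Cytotoxicity of ring-substituted ketone side chains in the series

The source may hold more compounds than are shown below. What is called first, only, known or untested is meant among the compounds shown, and "the series" means these compounds.

Measured compounds so far:
- compound 1 `CCC1=C(C(=O)CCC2CCCCCC2)[C@H](c2ccc(O)c(Cl)c2)NC(=O)N1`; in an ADME assay on cells (Homo sapiens) for cytotoxicity (on this read-out lower numbers stand for higher toxicity in this test and higher numbers for lower toxicity in this test), compound 1 is reported only as a limit, > 10000 nM.
- compound 2 `CCC1=C(C(=O)CCc2ccccc2)[C@H](c2ccc(O)c(Cl)c2)NC(=O)N1`; in this assay compound 2 is also reported only as a limit, > 10000 nM.
- compound 3 `CCC1=C(C(=O)CC2CCCC2)[C@H](c2ccc(O)c(Cl)c2)NC(=O)N1`; in this assay compound 3 likewise gives only a limit, > 10000 nM.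

Compound 3 therefore stands at the same limit as the other two, and no order among the three can be read, as the limit of > 10000 nM in this assay, at which 3 of the 3 values shown sit, makes plain. The unmeasured compound 4 `CCC1=C(C(=O)CC2CCCCC2)[C@H](c2ccc(O)c(Cl)c2)NC(=O)N1` differs from compound 3 by cyclohexyl in place of cyclopentyl on a saturated chain carbon bound to a carbonyl carbon.

The steps that touch the same position are a step that the two limits leave unreadable from compound 1 to compound 3 and a step that the two limits leave unreadable from compound 2 to compound 3, and a step that the two limits leave unreadable from compound 1 to compound 2 adds nothing readable either. None of them carries a size, so no direction can be derived for the present change, and the expectation is that compound 4 also sits at the limit in this assay. The step that the limit leaves unreadable from compound 3 to compound 4 is accordingly estimated to be flat. For compound 4 the estimate is 20000 nM, with a range from 10000 nM to 60000 nM.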

Compound 4, half-maximal cytotoxic concentration: > 10000 nM
Compound 4: no number, only a limit; the forecaster's own chance of this, stated with the estimate: 85%; the middle value does not contradict the limit.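

In this assay, within the data shown here, compound 4 gives only a limit, > 10000 nM, so no step to it from compound 1, compound 2 or compound 3 can be read: the limit of > 10000 nM in this assay, at which 4 of the 4 values shown sit. The compounds shown leave open whether these four side chains differ at all in this assay.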